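The compounds below may be only part of what the source reports. "The series", "measured", "known", "first", "only" and "open" are said of these compounds alone.

Measured in an assay on membranes from Cerebral cortex for displacement of a labelled ligand from Neuronal acetylcholine receptor; alpha4/beta2 (Rattus norvegicus); a higher number here means a weaker inhibitor, a lower number a stronger inhibitor:
- compound 2, `O=C(Nc1ccc(F)cc1F)c1cncc(N2CC3CC(C2)N3)c1`: 0.051 nM
- compound 3, `O=C(c1cncc(N2CC3CC(C2)N3)c1)N1CCCc2ccccc21`: 0.196 nM
- compound 1, `COc1cc(NC(=O)c2cncc(N3CC4CC(C3)N4)c2)cc(OC)c1`: 0.985 nM

Compound 2 gives the lowest number of the three in this assay. Compound 3 is its nearest neighbour and compound 1 the furthest; both of those gaps lie beyond the usual scatter, so compound 2 is the strongest inhibitor of the set as measured. All three share the same core; they differ only in the group carried by the amide.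

Compound 4, `O=C(Nc1cccc(F)c1)c1cncc(N2CC3CC(C2)N3)c1`, has not been measured. It is reached from compound 2 by one change: 3-fluorophenyl in place of 2,4-difluorophenyl on an amide-type nitrogen. Within the data shown here, no pair of measured compounds differs in one place, so there is no measured step to lean on for this particular exchange. What is known is that compound 2 sits far below compound 1 and compound 3, and that compound 4 keeps the anilide form of compound 2 rather than moving toward either of those.

In this assay the step from compound 2 to compound 4 is expected to be a modest loss, a 2.9-fold higher number from compound 2 to compound 4 (0.47 log units; beyond the scatter), possibly within scatter, because compound 2 gives 0.051 nM and the change is small. Compound 4 is estimated at 0.15 nM, with a range from 0.04 nM to 0.6 nM.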

Compound 4, inhibition constant: 0.044 nM
Estimate against measurement, compound 4: 3.4-fold (0.53 log units) above, within the range that was stated.
By their numbers in this assay, from the lowest: compounds 4 and 2 (each within the scatter of the next); then compound 3; then compound 1.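

In this assay, among these compounds, 3-fluorophenyl in place of 2,4-difluorophenyl on the amide-type nitrogen gives a 1.2-fold lower number from compound 2 to compound 4 (0.06 log units; within the scatter), and this is the first step that differs in one place. The anilide position therefore accepts this exchange with no change that can be read, even though the group entering carries one fluorine and the group leaving carries two. Nothing measured here accounts for this result, and no data on the properties of the two groups are available.

On these data alone, this single exchange alters both the number of fluorines and the pattern in which they are placed, so the effect of each cannot be separated, and it remains open whether the anilide needs fluorine at all. A plain phenyl group, a 3-chlorophenyl group or a 3-methoxyphenyl group on the same amide-type nitrogen would test whether this tolerance extends beyond fluorine-bearing rings, and the compounds shown give no indication either way.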